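Amide aryl variation on the shared core: benzothiophene step

The source may report more compounds than this note shows. Statements on the series, on what has been measured and on what is new or still open speak of the compounds shown alone.

Compound 1 `CC(=O)Nc1cccc2c(-c3cccc(NC(=O)c4ccc(C)c(C)c4)c3)ccnc12` and compound 2 `CC(=O)Nc1cccc2c(-c3cccc(NC(=O)c4cc(C)oc4C)c3)ccnc12` share one core and differ only in the aryl group on the carbonyl carbon. In a functional assay on A375P cells (Homo sapiens) for antiproliferative activity, read by MTT assay, with a stated time of 48 h (on this read-out higher numbers stand for weaker inhibition and lower numbers for stronger inhibition), compound 1 gives only a limit, > 20000 nM. In this assay compound 2 likewise gives only a limit, > 20000 nM. The step that the two limits leave unreadable from compound 1 to compound 2 cannot be read in size or direction because of the limit of > 20000 nM in this assay, at which 2 of the 2 values shown sit. Compound 2 therefore stands at the limit of this assay, with no number of its own and no measured neighbour that gives one.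

Compound 3 `CC(=O)Nc1cccc2c(-c3cccc(NC(=O)c4cc5ccccc5s4)c3)ccnc12` carries 1-benzothiophen-2-yl in place of 2,5-dimethylfuran-3-yl on a carbonyl carbon. Going by the values given here, only one measured step concerns a change at this carbonyl carbon, a step that the two limits leave unreadable from compound 1 to compound 2, and it is unreadable, so no measured size can be carried over to the present change. With both measured compounds sitting at the limit, the expectation for compound 3 rests on that alone. Compound 3 is expected to give an estimated 20000 nM in this assay, within a range of 4000 nM to 60000 nM. The expected step of a number no higher from compound 2 to compound 3 (the limit leaves the size open) is thus taken as none beyond the scatter, with a high chance that this assay again returns only a limit.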

Compound 3, half-maximal inhibitory concentration: 9100 nM
Compound 3: middle estimate off by 2.2-fold (0.34 log units), on the high side; the range from low to high includes it.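

In this assay, going by these compounds alone, compound 3 gives 9100 nM, the first real number in this set, so the group on the carbonyl carbon can bring the read-out inside the measurable range, which the earlier pair could not show. The change from the 2,5-dimethylfuran-3-yl group to 1-benzothiophen-2-yl is an at least 2.1-fold lower number from compound 2 to compound 3 (0.34 log units; beyond the scatter), and the change from the 3,4-dimethylphenyl group to the same group is an at least 2.1-fold lower number from compound 1 to compound 3 (0.34 log units; beyond the scatter). Both steps are minimum sizes only, because their starting points are limits and not numbers: the limit of > 20000 nM in this assay, at which 2 of the 3 values shown sit.

The compounds shown do not separate the parts of the change, since the sulfur in place of oxygen, the added six-membered aromatic ring and the loss of the methyl groups all arrive together in compound 3. Going by these compounds, a thiophen-2-yl or a 1-benzofuran-2-yl group on the same carbonyl carbon would be the one-place comparison that could tell these apart, and whether any further gain lies beyond the 1-benzothiophen-2-yl group remains open.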